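This account rests on a few compounds, and the source may have more. Where it says the series, first, only, none or still open, it means among the compounds named here.

Measured so far:

Compound 1 `Nc1nc(O)c2c(n1)n(C1OC(CO)[C@@H](O)[C@H]1O)c(=O)n2Cc1ccc(Cl)cc1` — 27%
Compound 2 `CCCn1c(=O)n(C2CCC(CO)O2)c2nc(NC(=O)C(C)(C)C)nc(O)c21` — 0%
Compound 3 `C=CCn1c(=O)n(C2OC(CO[Si](C)(C)C(C)(C)C)[C@@H](O)[C@H]2O)c2nc(N)nc(O)c21` — 6%

Three compounds built on a shared core have been run through a functional assay on YAC-1 cells (Mus musculus); a lower number here means a smaller maximal response, a higher number a larger maximal response. Compound 1 gives 27%, the highest of the three numbers. Compound 3 comes nearest to it with 6%, a gap that lies beyond the usual scatter of this assay. Compound 2 lies furthest away with 0%, again beyond the scatter. No two of these compounds differ in only one place, so no single measured step can be read off as a guide.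

Compound 4 `N#Cc1ccc(Cn2c(=O)n(C3OC(CO)[C@@H](O)[C@H]3O)c3nc(N)nc(O)c32)cc1` has not yet been measured. It differs from compound 1 in one spot: cyano in place of chloro on an aromatic carbon. Among the measured compounds shown here, nothing among the measured compounds shows what this exchange does in this assay, so the expectation rests only on the fact that the rest of the molecule is kept exactly as in compound 1. The step from compound 1 to compound 4 is expected to be small, most likely within the scatter or a modest decrease, that is a number 7 percentage points lower from compound 1 to compound 4 (within the scatter). Compound 4 is therefore estimated at 20%, with a plausible range from 5% to 35%.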

Compound 4, largest response reached (reported as maximal response), in percent of the reference or control that the assay uses: 0%
Compound 4: the middle estimate sits 20 percentage points above what was measured; the whole stated range lies above it.
By their numbers in this assay, from the lowest: compounds 2, 4 and 3 (each within the scatter of the next); then compound 1.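

Among the compounds shown here, until now, no two compounds differed in only one place, so nothing showed how much a single change could matter in this assay. Replacing chloro with cyano on the aromatic carbon, para to a large group, gives a number 27 percentage points lower from compound 1 to compound 4 (beyond the scatter), so this one spot on the 4-chlorobenzyl group has a large influence on the read-out, even with the rest of the molecule kept the same: compound 4 stands at 0%, and the response seen with compound 1 is not kept. Nothing measured here accounts for the loss, so the step records what happens without explaining it.

A single exchange at one spot cannot show whether chloro is special or cyano is the problem, and a bromine atom, a methyl group, a methoxy group or plain hydrogen in the same place would help to separate those two readings. On these data alone, it also remains open whether the same exchange would have a similar effect on a compound with a different sugar part, such as one carrying a silyl ether.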